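Fluoro on the anilide ring of a thienopyrimidine ether

A few compounds are considered here, and "the series" means these few. Any claim that something is new, unique, unknown or untested is made for them only; others in the source may bear on it.

Measured compounds:
compound 1, `Cc1cc(=O)n(-c2ccc(Br)cc2F)nc1C(=O)Nc1ccc(Oc2ncnc3sccc23)cc1`, 6300 nM
compound 2, `Cc1cc(=O)n(-c2cccc(F)c2)nc1C(=O)Nc1ccc(Oc2ncnc3sccc23)cc1`, 18500 nM
compound 3, `Cc1ccc(-n2nc(C(=O)Nc3ccc(Oc4ncnc5sccc45)cc3)c(C)cc2=O)cc1`, > 40000 nM

Of the compounds shown here, three sharing one core have been tested in a functional assay on HepG2 cells (Homo sapiens) for cytotoxicity, read by MTT assay, with a stated time of 72 h; on this read-out higher numbers stand for weaker inhibition and lower numbers for stronger inhibition. Compound 1 gives 6300 nM, the lowest of the two numbers recorded. Compound 2 gives 18500 nM, which is a 2.9-fold higher number from compound 1 to compound 2 (0.47 log units; beyond the scatter). Compound 3 sits at a limit of the assay rather than a number, (the limit of > 40000 nM in this assay, at which 1 of the 3 values shown sits); for compound 3 the value is > 40000 nM. Against compound 1 that is an at least 6.3-fold higher number from compound 1 to compound 3 (0.80 log units; beyond the scatter), and against compound 2 it is an at least 2.1-fold higher number from compound 2 to compound 3 (0.33 log units; beyond the scatter). All three measured steps alter the aromatic group on the ring nitrogen.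

Compound 4, `Cc1cc(=O)n(-c2ccc(Br)cc2F)nc1C(=O)Nc1ccc(Oc2ncnc3sccc23)c(F)c1`, differs from compound 1 elsewhere: fluoro in place of hydrogen on an aromatic carbon, the fluoro placed on an aromatic carbon of a six-membered aromatic ring of carbon only, ortho to a large group and meta to a large group. Going by the values given here, none of the measured steps touches this ring, so no measured step bears directly on the change. On that basis the step from compound 1 to compound 4 is expected to lie within the scatter, a 1.1-fold lower number from compound 1 to compound 4 (0.02 log units; within the scatter). Compound 4 is therefore estimated at 6000 nM, within a range of 2500 nM to 15000 nM.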

Compound 4, half-maximal inhibitory concentration: 13800 nM
Estimate against measurement, compound 4: 2.3-fold (0.36 log units) below; measured number inside the range.
By their numbers in this assay, from the lowest: compound 1; then compounds 4 and 2 (each within the scatter of the next). At a limit, above all of these: compound 3.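

In this assay, the six-membered aromatic ring of carbon only that carries the amide nitrogen turns out to be a position where a very small change can be read: fluoro in place of hydrogen on an aromatic carbon, ortho to a large group and meta to a large group, gives a 2.2-fold higher number from compound 1 to compound 4 (0.34 log units; beyond the scatter). Going by these compounds alone, the earlier steps all altered the aromatic group on the ring nitrogen, so this is the first sign that a change elsewhere on the shared core also moves the number beyond the scatter, here modestly and towards weaker inhibition, with only one heavy atom entering. Nothing measured here bears on why this single fluoro has that effect.

The compounds shown leave open whether a chloro, a methyl, a methoxy or an amino group on this same carbon would give a step of similar size and direction, and whether fluoro on the other carbons of this ring would do the same. They also leave open whether this fluoro would give a comparable step with the 3-fluorophenyl group of compound 2 on the ring nitrogen.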